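Removing the dimethylpentenyl chain from compound 2

A few compounds are considered here, and "the series" means these few. Any claim that something is new, unique, unknown or untested is made for them only; others in the source may bear on it.

Measured in an assay on nucleic acid for binding affinity to Nucleic Acid, read by fluorescence; on this read-out higher numbers stand for an effect only at larger amounts of compound and lower numbers for an effect already at smaller amounts:
- compound 1 `NCCCC[C@H](N)C(=O)N[C@@H]1C[C@H](N)[C@@]2(CC[C@H](O)[C@H](O)CO2)[C@H](O)[C@H]1O`: 12000 nM
- compound 2 `C=CCC(C)(C)CN[C@@H]1C[C@H](N)[C@@]2(CCC=CCO2)[C@H](O)[C@H]1O`: 63000 nM
- compound 3 `N[C@@H]1C[C@H](N)[C@@]2(CC[C@@H](O)[C@@H](O)CO2)[C@H](O)[C@H]1O`: 141000 nM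

Compound 2, at 63000 nM, has the second highest of the three numbers, with compound 3 higher and compound 1 lower, both beyond the scatter. Compound 4 `N[C@@H]1C[C@H](N)[C@@]2(CCC=CCO2)[C@H](O)[C@H]1O` carries hydrogen in place of 2,2-dimethylpent-4-en-1-yl on an amine nitrogen. Within the data shown here, no measured pair isolates this change. Compound 3 also lacks the chain on that nitrogen and shows 141000 nM, so a modest move towards a higher number is expected. The estimated step is a 2.1-fold higher number from compound 2 to compound 4 (0.31 log units; beyond the scatter). For compound 4 the estimated value is 130000 nM, with an expected range of 50000 nM to 350000 nM.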

Compound 4, half-maximal effective concentration: 8400 nM
Beside the measured number, compound 4's estimate is 15-fold (1.19 log units) above it, outside the stated range (below it).
By their numbers in this assay, from the lowest: compounds 4 and 1 (each within the scatter of the next); then compound 2; then compound 3.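

In this assay, hydrogen in place of 2,2-dimethylpent-4-en-1-yl on an amine nitrogen gives a 7.5-fold lower number from compound 2 to compound 4 (0.88 log units; beyond the scatter) and so moves the number towards effect at smaller amounts. This position therefore responds to the substituent, and on this core the chain is not needed for the read-out and goes with a higher number. Nothing available accounts for the size or direction of this step.

As far as these compounds go, whether a shorter ethyl group or a 2-aminoethyl chain on that nitrogen would keep the number of compound 4 remains open. Also open, from the compounds shown here alone, is whether the same change gives a similar step on the core of compound 3.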